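Dropping a Fluoro Substituent: From Compound 2 to Compound 3

The source may report more compounds than this note shows. Statements on the series, on what has been measured and on what is new or still open speak of the compounds shown alone.

Of the compounds shown here, two have numbers so far. Compound 1 `O=C(NO)c1cccc(/C=C/c2ccnc(-c3ccccc3O)c2)c1` and compound 2 `O=C(NO)c1ccc(/C=C/c2ccnc(-c3cc(F)ccc3O)c2)cc1` were both tested in an assay on isolated protein for inhibition of protein deacetylase HDAC6 (Homo sapiens), read by fluorescence, with a stated time of 15 min; a lower number here means a stronger inhibitor, a higher number a weaker inhibitor. In this assay compound 1 gives 390 nM, while compound 2 gives 130 nM, the lowest of the two numbers; the nearest, compound 1, sits a good deal higher, a gap beyond the scatter. The two compounds differ in more than one place, so no single change can be read from that gap.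

Compound 3 `O=C(NO)c1ccc(/C=C/c2ccnc(-c3ccccc3O)c2)cc1` is not yet measured. It differs from compound 2 in one place: hydrogen in place of fluoro on an aromatic carbon. The rest of the molecule, including the hydroxamic acid and the shared core, stays as in compound 2.

For the measured compounds named here, no measured pair isolates this change. A lone fluorine leaving an aromatic ring is a small edit, and the step from compound 2 is expected to be modest, probably a slight loss within or near the scatter, a 1.5-fold higher number from compound 2 to compound 3 (0.16 log units; within the scatter). Compound 3 is therefore estimated at 190 nM in this assay, with a range of 70 nM to 500 nM.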

Compound 3, half-maximal inhibitory concentration: 47 nM
Estimate against measurement, compound 3: 4.0-fold (0.61 log units) above, and the stated range ends above it.
By their numbers in this assay, from the lowest: compound 3; then compound 2; then compound 1.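

In this assay, for the compounds shown here, this is the first pair that isolates a single edit, and going from 5-fluoro-2-hydroxyphenyl to 2-hydroxyphenyl proves not to be neutral: removing the fluoro gives a 2.8-fold lower number from compound 2 to compound 3 (0.44 log units; beyond the scatter). On this aromatic carbon, para to a hydroxy group, hydrogen therefore serves better than fluoro in this pair, and the plain 2-hydroxyphenyl compound 3 now stands first in the order of the three. Yet compound 1 carries the same 2-hydroxyphenyl and gives 390 nM, so the absence of fluoro does not by itself bring a low number.

Nothing available explains why the number moves with this edit. As far as these compounds go, whether the trend extends to other substituents on the same carbon, such as chloro, methyl or methoxy, remains open, as does whether an amine could take the place of the hydroxy group while the hydrogen stays.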